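The compounds below may be only part of what the source reports. "The series", "measured", "known", "first", "only" and "open" are said of these compounds alone.

Measured compounds:
Compound 1 `Brc1ccc(C2=NN(c3nc(-c4ccc(Br)cc4)cs3)C(c3cccs3)C2)cc1` gives 28300 nM in a functional assay on MCF7 cells (Homo sapiens) for antiproliferative activity, read by MTT assay, with a stated time of 48 h; a higher number here means a weaker inhibitor, a lower number a stronger inhibitor.
Compound 2 `Brc1ccc(C2=NN(c3nc(-c4ccccc4)cs3)C(c3cccs3)C2)cc1` gives 6790 nM in this assay.
Compound 3 `Clc1ccc(C2=NN(c3nc(-c4ccc(Br)cc4)cs3)C(c3cccs3)C2)cc1` gives 14700 nM in this assay.

Compound 1 and compound 2 differ by hydrogen in place of bromo on an aromatic carbon, and this change made a step of a 4.2-fold lower number from compound 1 to compound 2 (0.62 log units; beyond the scatter). Compound 3 stands on a core that differs from that of compound 1 by chloro in place of bromo on an aromatic carbon, a step of a 1.9-fold lower number from compound 1 to compound 3 (0.28 log units; within the scatter). Compound 4 `Clc1ccc(C2=NN(c3nc(-c4ccccc4)cs3)C(c3cccs3)C2)cc1` has not been measured; it differs from compound 3 by hydrogen in place of bromo on an aromatic carbon, the same change at the same place as between compound 1 and compound 2. Among the compounds with values here, the expected step here is a 3.7-fold lower number from compound 3 to compound 4 (0.57 log units; beyond the scatter), kept close to the earlier one because a 4.2-fold lower number from compound 1 to compound 2 (0.62 log units; beyond the scatter) is the only measured instance of this change and the two cores differ only by chloro in place of bromo on an aromatic carbon. Compound 4 is therefore estimated at 4000 nM, expected to fall between 1500 nM and 11000 nM.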

Compound 4, half-maximal inhibitory concentration: 190 nM
Compound 4: middle estimate off by 21-fold (1.32 log units), on the high side, outside the stated range (below it).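

In this assay, going from 4-bromophenyl to phenyl gives a 77-fold lower number from compound 3 to compound 4 (1.89 log units; beyond the scatter), far larger than the same change on the core of compound 1, so the size of this step does not carry from one core to the other: the same change on two cores in this assay, a 4.2-fold lower number (0.62 log units; beyond the scatter) from compound 1 to compound 2 and a 77-fold lower number (1.89 log units; beyond the scatter) from compound 3 to compound 4, 19-fold (1.27 log units) apart, beyond the scatter of two such steps. Chloro in place of bromo gives a 36-fold lower number from compound 2 to compound 4 (1.55 log units; beyond the scatter) where the phenyl is present, far more than where the 4-bromophenyl is present, so the two changes do not simply add up: the same change on two cores in this assay, a 1.9-fold lower number (0.28 log units; within the scatter) from compound 1 to compound 3 and a 36-fold lower number (1.55 log units; beyond the scatter) from compound 2 to compound 4, 19-fold (1.27 log units) apart, beyond the scatter of two such steps. The change lowers the number on both cores, but these four compounds do not show why the sizes differ, nor how it would behave on any other core.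

Going by these compounds, it remains open whether this large step is special to chloro, and a fluoro or a methoxy group in its place would test that.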